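The compounds below may be only part of what the source reports. "The series", "measured", "known", "first", "only" and "open" are said of these compounds alone.

Compound 1 `COc1ccc2ncc(S(=O)(=O)c3ccc(Cl)cc3)c(N3CCC(C)CC3)c2c1` is the reference point of this set. In an assay on isolated protein for displacement of a labelled ligand from metabotropic glutamate receptor 5 (Homo sapiens), with a stated time of 60 min, tested at 1 uM (on this read-out lower numbers stand for less inhibition and higher numbers for more inhibition at the one concentration tested (going by the name of the read-out)), compound 1 gives 91%. Compound 2 `COc1ccc2ncc(S(=O)(=O)c3ccc(Cl)c(Cl)c3)c(N3CCC(C)CC3)c2c1` differs from it only in one spot, (chloro in place of hydrogen on an aromatic carbon), and in this assay compound 2 gives 87%, so that a number 4 percentage points lower from compound 1 to compound 2 (within the scatter). Compound 3 `CC1CCN(c2c(S(=O)(=O)c3ccccc3)cnc3c(F)cccc23)CC1` carries a different core, and the difference between the two cores is not broken down here. In this assay compound 3 gives 13%, the lowest of the three numbers, with compound 2 the nearest to it and compound 1 the furthest.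

Compound 4 `CC1CCN(c2c(S(=O)(=O)c3ccc(Cl)cc3)cnc3c(F)cccc23)CC1` has not yet been measured. It differs from compound 3 in one spot, (chloro in place of hydrogen on an aromatic carbon). For the measured compounds named here, this is the same kind of change as the one from compound 1 to compound 2, but not the same: there the entering chloro sat ortho to a chloro group and meta to a large group, whereas here it sits para to a large group, and the wider reading of the change is phenyl to 4-chlorophenyl rather than 4-chlorophenyl to 3,4-dichlorophenyl. The earlier step was within the scatter. For compound 4 the author expects a number 17 percentage points higher from compound 3 to compound 4 (beyond the scatter), a modest rise, because compound 3 starts from 13% and the chloro it gains matches the chloro that compound 1 carries at 91%, though on another core. In this assay compound 4 is therefore estimated at 30%, between 5% and 65%.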

Compound 4, a percentage reported as inhibition, at one concentration (the size of the read-out at that concentration, not a potency): 85%
Compound 4: middle estimate off by 55 percentage points, on the low side, outside the stated range (above it).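

In this assay, chloro in place of hydrogen on an aromatic carbon gives a number 72 percentage points higher from compound 3 to compound 4 (beyond the scatter) and so does not behave as a change of one fixed size across the two cores: the same change on two cores in this assay, a number 4 percentage points lower (within the scatter) from compound 1 to compound 2 and a number 72 percentage points higher (beyond the scatter) from compound 3 to compound 4, 76 percentage points apart, beyond the scatter of two such steps. The comparison is not a clean test of the core alone, since in the newer step the chloro enters an unsubstituted phenyl and sits para to a large group, whereas in the earlier step it enters a ring that already carries a chloro. For the compounds shown here, the result therefore shows that the size of this step cannot simply be carried from one pair to the other, but with only two steps it does not show whether the core, the place of the chloro or the starting ring accounts for the gap.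

The compounds shown leave open how an unsubstituted phenyl would read on the core of compound 1 and how a 3,4-dichlorophenyl would read on the core of compound 3, the two pairings that would separate core from place. They also leave open whether a bromo, a methoxy, a nitrile or an amine in the place of that chloro would give a similar reading.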